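Notes on a series: hydroxy to methoxymethyl at one aromatic carbon

The source may hold more compounds than are shown below. What is called first, only, known or untested is meant among the compounds shown, and "the series" means these compounds.

Measured in a functional assay on MCF7 cells (Homo sapiens) for cytotoxicity, read by neutral red uptake, with a stated time of 3 days; a higher number here means a weaker inhibitor, a lower number a stronger inhibitor:
Compound 1 `CCCCCCc1c(F)c(N)c2c(=O)cc(-c3ccc(N)c(F)c3)oc2c1F` gives > 10000 nM, a limit of the assay.
Compound 2 `Nc1ccc(-c2cc(=O)c3c(N)c(F)c(O)c(F)c3o2)cc1F` gives > 10000 nM, also a limit.
Compound 3 `CN(C)CCCC(=O)OCc1c(F)c(N)c2c(=O)cc(-c3ccc(N)c(F)c3)oc2c1F` gives 29 nM.

Compound 2 stands at the limit of > 10000 nM in this assay, at which 2 of the 3 values shown sit; its value is a limit, not a number, and a step that the two limits leave unreadable from compound 1 to compound 2 therefore stays unreadable. The readable steps are an at least 340-fold lower number from compound 1 to compound 3 (2.53 log units; beyond the scatter) and an at least 340-fold lower number from compound 2 to compound 3 (2.53 log units; beyond the scatter). Compound 4 `COCc1c(F)c(N)c2c(=O)cc(-c3ccc(N)c(F)c3)oc2c1F` carries the change (methoxymethyl in place of hydroxy on an aromatic carbon). For the measured compounds named here, the ((3-(dimethylamino)propyl)carbonyl)oxy part that enters in compound 3 is absent from compound 4, and no measured step shows a methoxymethyl. A small step of an at least 1.2-fold lower number from compound 2 to compound 4 (0.09 log units; that floor lies within the scatter) is expected, with a fair chance that compound 4 again yields only a limit. Compound 4 is estimated at 8000 nM, with a range from 1500 nM to 30000 nM.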

Compound 4, half-maximal inhibitory concentration: 46 nM
For compound 4 the middle estimate is 170-fold (2.24 log units) above the measured one; the whole stated range lies above it.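

In this assay, a small ether side chain at this aromatic carbon is enough for a low number, with an at least 210-fold lower number from compound 2 to compound 4 (2.33 log units; beyond the scatter) and, against the hexyl chain, an at least 210-fold lower number from compound 1 to compound 4 (2.33 log units; beyond the scatter). Both steps are floors, as compounds 1 and 2 stand at a limit: the limit of > 10000 nM in this assay, at which 2 of the 4 values shown sit.

The (3-(dimethylamino)propyl)carbonyl group of compound 3 is not needed for a low number here, with methyl in its place giving a 1.6-fold higher number from compound 3 to compound 4 (0.20 log units; within the scatter).

From the compounds shown here alone, what a hydroxymethyl, an aminomethyl or a plain ethyl at this aromatic carbon would give stays open. So does whether the chain oxygen itself matters.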